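The source may report more compounds than this note shows. Statements on the series, on what has been measured and on what is new or still open speak of the compounds shown alone.

Compound 1 `C/C(=N\O)C(=O)NCCCCCC(=O)Nc1ccccc1` is the starting point. In a functional assay on HCT-116 cells (Homo sapiens) for inhibition, read by colorimetric assay, with a stated time of 3 days (a higher number here means a weaker inhibitor, a lower number a stronger inhibitor), compound 1 gives only a limit, > 100000 nM, and not a number. The two other values known in this assay are limits as well. Compound 2 `CC(=O)C(=O)NCCCCCCC(=O)Nc1ccccc1` in this assay gives a limit of > 100000 nM. Compound 3 `O=C(CCCCCCC(O)C(F)(F)F)Nc1ccccc1` in this assay gives a limit of > 40000 nM. The steps among these three, a step that the two limits leave unreadable from compound 1 to compound 2, a step that the two limits leave unreadable from compound 1 to compound 3 and a step that the two limits leave unreadable from compound 2 to compound 3, cannot be read in size or direction: every value shown sits at a limit, either the limit of > 100000 nM in this assay, at which 2 of the 3 values shown sit, or (the limit of > 40000 nM in this assay, at which 1 of the 3 values shown sits).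

Compound 4 `O=C(CCCCCNC(=O)c1ccc[nH]1)Nc1ccccc1` differs from compound 1 by a group of 5 heavy atoms (4 carbon, 1 nitrogen; one five-membered aromatic ring with 1 hetero atom) in place of a group of 4 heavy atoms (2 carbon, 1 nitrogen, 1 oxygen; no ring), on a carbonyl carbon. Among the compounds with values here, none of the measured steps touches the carbonyl carbon where this change sits, and none of them is readable, so they offer no direction and no size to carry over. With nothing measured that points to a gain, compound 4 is expected to remain at the limit, which corresponds to an estimated step of a number no higher from compound 1 to compound 4 (the limit leaves the size open). The estimate for compound 4 in this assay is 100000 nM, with a range from 30000 nM to 300000 nM.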

Compound 4, half-maximal inhibitory concentration: > 100000 nM
Compound 4 ended at the assay's limit (the forecaster's own chance of this, stated with the estimate: 80%); the middle value lies on the limit itself.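

In this assay compound 4 gives > 100000 nM, a limit and not a number. Compound 1 also stands only at a limit, so the step between compound 1 and compound 4 cannot be read. The compounds shown leave open which group, if any, would give a measurable value in this assay.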